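Compound 2 to compound 4: a step at the limit

This account rests on a few compounds, and the source may have more. Where it says the series, first, only, none or still open, it means among the compounds named here.

Measured so far in a physicochemical assay for solubility, at pH 7; a higher number here means a more soluble compound, a lower number a less soluble compound:
Compound 1 `CC1(C)c2[nH]nc(NC(=O)c3ccc(F)cc3)c2CN1C(=O)C1CCN(C2CC2)CC1` gives > 225000 nM
Compound 2 `CN1CCC(C(=O)N2Cc3c(NC(=O)c4cc(F)cc(F)c4)n[nH]c3C2(C)C)CC1` gives > 225000 nM
Compound 3 `CN(C)CC(=O)Nc1n[nH]c2c1CN(C(=O)C(C)(C)C)C2(C)C` gives > 225000 nM

Compound 2 stands at > 225000 nM and this is a limit, not a number. Compound 1 and compound 3 are reported in the same way, so the series offers no numerical reading yet. Among the compounds with values here, the whole picture is the limit of > 225000 nM in this assay, at which 3 of the 3 values shown sit, and no compound can be ranked against another.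

Compound 4 `CN1CCC(C(=O)N2Cc3c(NC(=O)Nc4cccc(F)c4)n[nH]c3C2(C)C)CC1` has not yet been measured. It differs from compound 2 in one place (3-fluorophenyl)amino in place of 3,5-difluorophenyl on a carbonyl carbon with (3-fluorophenyl)amino in place of 3,5-difluorophenyl on a carbonyl carbon. Cut one bond further out, the same difference reads (3,5-difluorophenyl)carbonyl to (3-fluorophenyl)carbamoyl. Within the data shown here, no two measured compounds differ in one place only, so no measured step can be carried over to this change. The expectation rests instead on the limit of > 225000 nM in this assay, at which 3 of the 3 values shown sit, and on the close likeness of compound 4 to compound 2.

In this assay the estimated step of an at least 1.1-fold lower number from compound 2 to compound 4 (0.05 log units; that floor lies within the scatter) is expected to stay within the usual scatter, with no clear direction. Compound 4 is estimated at 200000 nM with an expected range from 100000 nM to 225000 nM when it is measured.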

Compound 4, solubility: > 225000 nM
Compound 4: a limit, no number; the forecaster's own chance of this, stated with the estimate: 65%; at least 1.1-fold (0.05 log units) between middle value and limit.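

In this assay compound 4 gives > 225000 nM, which is a limit and not a number. Compound 2 is also reported only as a limit, so no step can be read between compound 2 and compound 4. The compounds shown leave open where any true value lies and how they rank, as all of them share one reading: the limit of > 225000 nM in this assay, at which 4 of the 4 values shown sit.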